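Methyl ester versus free acid on two cores

A few compounds are considered here, and "the series" means these few. Any claim that something is new, unique, unknown or untested is made for them only; others in the source may bear on it.

Compound 1 `C=C1CC[C@@H]2[C@](C)(CCC[C@]2(C)C(=O)O)[C@H]1CCc1ccc2c(OC(C)=O)ccc(OC(C)=O)c2c1` and compound 2 `C=C1CC[C@@H]2[C@](C)(CCC[C@]2(C)C(=O)OC)[C@H]1CCc1ccc2c(OC(C)=O)ccc(OC(C)=O)c2c1` share one core; compound 3 `C=C1CC[C@@H]2[C@](C)(CCC[C@]2(C)C(=O)O)[C@H]1CCC1=CCc2c(OC(C)=O)ccc(OC(C)=O)c2C1` carries a different core, and the difference between the two cores is not broken down here. In a functional assay on MEL28 cells (Homo sapiens) for cytotoxicity, read by sulforhodamine B assay, with a stated time of 72 h (on this read-out lower numbers stand for stronger inhibition of growth and higher numbers for weaker inhibition of growth), compound 1 gives 240 nM, and compound 2 gives 120 nM; the change methyl in place of hydrogen on an oxygen next to a carbonyl group made a 2.0-fold lower number from compound 1 to compound 2 (0.30 log units; within the scatter). Compound 3 gives 5000 nM, the highest number of the three, beyond the scatter from both compound 1 and compound 2. Compound 4 `C=C1CC[C@@H]2[C@](C)(CCC[C@]2(C)C(=O)OC)[C@H]1CCC1=CCc2c(OC(C)=O)ccc(OC(C)=O)c2C1` is not yet measured; it differs from compound 3 by methyl in place of hydrogen on an oxygen next to a carbonyl group, the same change as between compound 1 and compound 2, at the same place. For compound 4 the expected step in this assay is a 1.7-fold lower number from compound 3 to compound 4 (0.22 log units; within the scatter), resting on a 2.0-fold lower number from compound 1 to compound 2 (0.30 log units; within the scatter). Compound 4 is therefore estimated at 3000 nM, between 1500 nM and 7000 nM.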

Compound 4, concentration for 50% growth inhibition: 680 nM
Estimate against measurement, compound 4: 4.4-fold (0.64 log units) above, outside the stated range (below it).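

In this assay, methyl in place of hydrogen on an oxygen next to a carbonyl group gives a 7.4-fold lower number from compound 3 to compound 4 (0.87 log units; beyond the scatter), and the size of the step does not carry over from one core to the other: the same change on two cores in this assay, a 2.0-fold lower number (0.30 log units; within the scatter) from compound 1 to compound 2 and a 7.4-fold lower number (0.87 log units; beyond the scatter) from compound 3 to compound 4, 3.7-fold (0.57 log units) apart, beyond the scatter of two such steps. An estimate for this change on a further core therefore cannot simply borrow the size of a step seen on another core. Two cores give no general rule, and these compounds do not show which feature of the cores goes with the larger step.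

Going by these compounds, whether an ethyl ester or an amide at the same place would also give steps of differing size on the two cores stays open.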